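The compounds below may be only part of what the source reports. "The series", "measured", "known", "first", "only" and "open" are said of these compounds alone.

Measured in an ADME assay on THP-1 cells (Homo sapiens) for cytotoxicity, read by flow cytometry and propidium iodide staining, with a stated time of 72 h; on this read-out higher numbers stand for weaker inhibition and lower numbers for stronger inhibition:
- compound 1 `Nc1ccc2oc(-c3cccc(C(F)(F)F)c3)cc(=O)c2c1`: 34000 nM
- compound 2 `Nc1ccc2oc(-c3cccc(F)c3)c(O)c(=O)c2c1`: 30000 nM

In this assay compound 2 gives 30000 nM, which lies within the usual scatter of compound 1 at 34000 nM. Among the compounds with values here, the two numbers therefore set no order between these compounds.

Compound 3 `Nc1ccc2oc(-c3cccc(C(F)(F)F)c3)c(O)c(=O)c2c1` differs from compound 2 by trifluoromethyl in place of fluoro on an aromatic carbon, with trifluoromethyl in place of fluoro on an aromatic carbon. Within the data shown here, no measured pair isolates this exchange, so its size in this assay is not known. Among the measured compounds shown here, compound 1 also carries trifluoromethyl, and its value of 34000 nM offers the only guide. No step beyond the scatter, in either direction, is expected. The expected change is no change at the digits printed from compound 2 to compound 3 (within the scatter). For compound 3 the estimated value is 30000 nM, with an expected range of 13000 nM to 65000 nM.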

Compound 3, half-maximal inhibitory concentration: 2000 nM
Compound 3: the middle estimate sits 15-fold (1.18 log units) above what was measured; the whole stated range lies above it.
By their numbers in this assay, from the lowest: compound 3; then compounds 2 and 1 (each within the scatter of the next).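

In this assay, the exchange of fluoro for trifluoromethyl on this aromatic carbon, meta to a large group, gives a 15-fold lower number from compound 2 to compound 3 (1.18 log units; beyond the scatter) and shows that the read-out responds strongly to the group at this place. Hydroxy in place of hydrogen on an aromatic carbon gives a 17-fold lower number from compound 1 to compound 3 (1.23 log units; beyond the scatter), so trifluoromethyl alone does not produce the low number, and among these three compounds it appears only where trifluoromethyl and hydroxy occur together. Nothing available here accounts for the size of either step.

Open, on these data alone, is whether this drop is particular to trifluoromethyl or would also appear with chloro, methyl or a nitrile at the same place. Also open, as far as these compounds go, is whether a methoxy group could stand in for the hydroxy group on the shared core.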